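The source may report more compounds than this note shows. Statements on the series, on what has been measured and on what is new or still open speak of the compounds shown alone.

Measured in a functional assay on HCT-116 cells (Homo sapiens) for antiproliferative activity, read by CCK-8 assay, with a stated time of 72 h, tested at 2 uM; a lower number here means a weaker effect, a higher number a stronger effect of the compound at the concentration tested:

compound 1 `CCCCn1cnc2c(Nc3ccccc3)nc(NCOCc3ccc(/C=C/C(=O)Nc4ccccc4N)cc3)nc21` gives 6.58%
compound 2 `Nc1ccccc1NC(=O)c1ccc(CNc2nc(Cl)nc3c2ncn3Cc2ccccc2)cc1` gives 7.7%
compound 3 `CC(C)n1cnc2c(Nc3ccccc3)nc(NCOCc3ccc(C(=O)Nc4ccccc4N)cc3)nc21` gives 6.85%

All three numbers in this assay sit close together. Compound 2 has the largest figure of the three, but its distance to compound 3 and to compound 1 is within the usual scatter of this kind of measurement, so no ordering among them can be read from these values; the whole set reads as a weak effect at the tested concentration.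

The next compound, compound 4 `CCCCn1cnc2c(NCc3ccc(C(=O)Nc4ccccc4N)cc3)nc(Cl)nc21`, has not yet been measured in this assay. Against compound 2 it differs in one place: propyl in place of phenyl on a saturated chain carbon bound to an aromatic nitrogen. For the measured compounds named here, no pair of measured compounds differs in a single place, so there is no measured step of this type to lean on; what the three measured compounds do show is that rather different substitution patterns around the shared core all land at about the same low figure.

On that basis the step from compound 2 to compound 4 is expected to be small, a number 0.7 percentage points lower from compound 2 to compound 4 (within the scatter), in no particular direction and not beyond the scatter. Compound 4 is estimated at 7%, with a range from 1% to 16%.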

Compound 4, a percentage reported as inhibition, at one concentration (the size of the read-out at that concentration, not a potency): 4.89%
The estimate for compound 4 lay 2.1 percentage points above the measured number; the range from low to high includes it.
By their numbers in this assay, from the lowest: compounds 4, 1, 3 and 2 (each within the scatter of the next).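

In this assay, for the compounds shown here, propyl in place of phenyl on a saturated chain carbon bound to an aromatic nitrogen gives the first single-place step, a number 2.8 percentage points lower from compound 2 to compound 4 (within the scatter); cut one bond further out, the same difference reads benzyl to butyl. Going by these compounds alone, the six-membered aromatic ring at this place can therefore be exchanged for an open chain of carbon only without a shift beyond the scatter, which the earlier compounds, with no single-place pair among them, could not show. Both members of the pair remain weak at the tested concentration, and no measured property bears on the step, so nothing can be said about its origin.

A single concentration at this low level of effect leaves open whether compound 2 and compound 4 would also stay together at a level of effect where differences could be resolved. From the compounds shown here alone, it also remains open whether a carboxylic acid, an amine or a longer chain at this place, with the rest of compound 4 unchanged, would give a read-out beyond the scatter.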